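Phenoxy for methoxycarbonyl on the anilide: an expected quiet step

A few compounds are considered here, and "the series" means these few. Any claim that something is new, unique, unknown or untested is made for them only; others in the source may bear on it.

Compound 1 `COC(=O)c1cccc(NC(=O)C2CCCN(C(=O)c3cc(C(F)(F)F)cc(C(F)(F)F)c3)C2)c1` was run in an ADME assay on PC-3 cells (Homo sapiens) for cytotoxicity, read by WST assay, tested at 100 uM (a lower number here means less inhibition, a higher number more inhibition at the concentration tested (going by the name of the read-out)), and gives 0%. Compound 2 `O=C(Nc1cccc(Cc2ccccc2)c1)C1CCCN(C(=O)c2cccc(-c3ccco3)c2)C1` gives 0% in this assay, and compound 3 `COC(=O)c1cccc(C(=O)N2CCCC(C(=O)Nc3ccc(Cl)cc3)C2)c1` gives 0%. At the digits reported compound 1 stands level with compound 2 and compound 3; the nearest is compound 2 and the furthest compound 3, and neither gap reaches beyond the scatter. Among the measured compounds shown here, no pair among the three differs in a single place, so no single-change step can be read from the measured set. All three share the core of compound 1 and vary only in the aryl groups on the two amides.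

Compound 4 `O=C(Nc1cccc(Oc2ccccc2)c1)C1CCCN(C(=O)c2cc(C(F)(F)F)cc(C(F)(F)F)c2)C1` has not been measured in this assay. Relative to compound 1 the change is phenoxy in place of methoxycarbonyl on an aromatic carbon. The shared core has so far been silent in this assay whatever aryl groups it carries, and compound 1 itself gives 0%. The step of a number 2 percentage points higher from compound 1 to compound 4 (within the scatter) is therefore expected to stay within the scatter, with no direction to it. For compound 4 the estimated value is 2%, with a range from -8% to 15%.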

Compound 4, a percentage reported as inhibition, at one concentration (the size of the read-out at that concentration, not a potency): 1%
The estimate for compound 4 lay 1 percentage points above the measured number; low and high end bracket the measured number.
By their numbers in this assay, from the lowest: compounds 1, 2, 3 and 4 (each within the scatter of the next).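

Phenoxy in place of methoxycarbonyl on an aromatic carbon, meta to a large group, gives a number 1 percentage points higher from compound 1 to compound 4 (within the scatter) in this assay, and this is the first comparison in the series that isolates a single place. The earlier compounds shown here differ in several places at once, whereas this pair shows directly that, with the rest of compound 1 held fixed, the two groups cannot be told apart here, even though phenoxy has 7 heavy atoms and a six-membered aromatic ring of carbon only, against 4 heavy atoms and no ring for methoxycarbonyl. No available data bear on the reason for this result.

Going by these compounds, it remains open whether an amine or a carboxylic acid on this aromatic carbon would give a number beyond the scatter in this assay, or whether this position can move the read-out at all. Among the compounds shown here, all four compounds lie within the scatter of one another, so the series so far holds no member with a clear signal against which a change at this position could be sized.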